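Chloro in place of methoxy on the amide arm of compound 1

This account rests on a few compounds, and the source may have more. Where it says the series, first, only, none or still open, it means among the compounds named here.

Three members of this series have been measured. Compound 1 `COc1ccc(CNC(=O)/C=C/C=C/[C@H](O)Cc2ccc(OC)c(OC)c2)cc1` carries a benzylamide on the dienamide end of the shared core; in a functional assay on IMR-32 cells (Homo sapiens) for antiproliferative activity, read by sulforhodamine B assay, with a stated time of 48 h (a lower number here means a stronger inhibitor, a higher number a weaker inhibitor), compound 1 gives 17400 nM, the highest of the three numbers, although its nearest neighbour lies within the scatter. Compound 2 `COc1ccc(C[C@@H](O)/C=C/C=C/C(=O)N2CCN(c3ccccn3)CC2)cc1OC` gives 11100 nM, and compound 3 `COc1ccc(C[C@@H](O)/C=C/C=C/C(=O)N2CCN(c3ncccn3)CC2)cc1OC` gives 10800 nM; all three numbers sit within the scatter of one another, so no order among them can be read. For the measured compounds named here, the one step that joins two measured compounds, a 1.0-fold lower number from compound 2 to compound 3 (0.01 log units; within the scatter), replaces pyridin-2-yl with pyrimidin-2-yl on an amine nitrogen in a ring and stays within the scatter.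

Compound 4 `COc1ccc(C[C@@H](O)/C=C/C=C/C(=O)NCc2ccc(Cl)cc2)cc1OC` keeps the amide arm of compound 1 and differs from it by chloro in place of methoxy on an aromatic carbon. Going by the values given here, no measured step touches that part of the molecule, so nothing in the data speaks for or against a shift; the only measured step, from compound 2 to compound 3, was flat and lies elsewhere. He therefore expects compound 4 to stay near compound 1, with a step of a 1.2-fold lower number from compound 1 to compound 4 (0.06 log units; within the scatter) in this assay. His estimate for compound 4 is 15000 nM, with a range from 6000 nM to 38000 nM.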

Compound 4, half-maximal inhibitory concentration: 15700 nM
Estimate against measurement, compound 4: 1.0-fold (0.02 log units) below; low and high end bracket the measured number.
By their numbers in this assay, from the lowest: compounds 3, 2, 4 and 1 (each within the scatter of the next).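

Chloro in place of methoxy on the amide arm is the first measured step at this position, and this assay shows a 1.1-fold lower number from compound 1 to compound 4 (0.04 log units; within the scatter) for the change from 4-methoxybenzyl to 4-chlorobenzyl. The earlier compounds held no step on this aromatic carbon, para to a large group; the only earlier step lay on the other amide arm, so this position is now shown to tolerate the exchange of methoxy, with its hydrogen-bond acceptor and two heavy atoms, for chloro, with one heavy atom and no acceptor, without any change that can be read. No evidence is available that would account for this result.

What the compounds shown leave open is whether anything at this carbon can move the number beyond the scatter, such as an amine, a carboxylic acid or a longer chain in place of methoxy or chloro. Also open, from the compounds shown here alone, is whether the hydroxyl group or the two methoxy groups at the other end of the shared core matter more than the amide arm does.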